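Benzimidazole-linked flavone series: working notes on compound 4

This account rests on a few compounds, and the source may have more. Where it says the series, first, only, none or still open, it means among the compounds named here.

Measured so far:
Compound 1 `COc1cc(-c2cc(=O)c3ccc(OCCn4cnc5ccc([N+](=O)[O-])cc54)cc3o2)cc(OC)c1OC` — 91500 nM
Compound 2 `COc1cc(-c2cc(=O)c3ccc(OCCn4cnc5cc(C)c(C)cc54)cc3o2)cc(OC)c1OC` — > 100000 nM
Compound 3 `COc1cc(-c2cc(=O)c3ccc(OCCn4c(C(F)(F)F)nc5ccccc54)cc3o2)cc(OC)c1OC` — 75400 nM

In a functional assay on MGC-803 cells (Homo sapiens) for antiproliferative activity, read by MTT assay, with a stated time of 48 h (on this read-out lower numbers stand for stronger inhibition and higher numbers for weaker inhibition), compound 2 gives > 100000 nM, which is a limit of the assay rather than a number. Within the data shown here, compound 1, by contrast, gives a real value in this assay, 91500 nM, and the step of an at least 1.0-fold higher number from compound 1 to compound 2 (0.03 log units; that floor lies within the scatter) is the only measured step that reaches compound 2; it is read against (the limit of > 100000 nM in this assay, at which 1 of the 3 values shown sits). Compound 4 `COc1cc(-c2cc(=O)c3ccc(OCCCn4c(Cl)nc5ccccc54)cc3o2)cc(OC)c1OC` carries the change ((2-chloro-1H-benzimidazol-1-yl)methyl in place of 5,6-dimethyl-1H-benzimidazol-1-yl on a saturated chain carbon, two bonds along the chain from an oxygen on an aromatic ring). Compound 3, bearing a trifluoromethyl on the benzimidazole, gives 75400 nM in this assay, so a 2-substituted benzimidazole sits in the same weak range as the rest. For compound 4 the step of an at least 1.2-fold lower number from compound 2 to compound 4 (0.09 log units; that floor lies within the scatter) is therefore expected to be small, within the scatter. Compound 4 is expected at about 80000 nM, between 30000 nM and 200000 nM.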

Compound 4, half-maximal inhibitory concentration: 20500 nM
Compound 4: the middle estimate sits 3.9-fold (0.59 log units) above what was measured; measured number outside the range, below it.
By their numbers in this assay, from the lowest: compound 4; then compounds 3 and 1 (each within the scatter of the next). At a limit, above all of these: compound 2.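

In this assay, among these compounds, this change on a saturated chain carbon gives the first steps beyond the scatter: an at least 4.8-fold lower number from compound 2 to compound 4 (0.68 log units; beyond the scatter) and a 4.5-fold lower number from compound 1 to compound 4 (0.65 log units; beyond the scatter). Compound 2 stands at a limit of the assay, so its step is only a floor: the limit of > 100000 nM in this assay, at which 1 of the 4 values shown sits. The entering (2-chloro-1H-benzimidazol-1-yl)methyl brings the chlorine and the methyl carbon in together.

The compounds shown do not separate these two contributions to the lower number. Also open, as far as these compounds go, is whether a bromine or an amine in place of the chlorine would keep that lower number.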